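The source may hold more compounds than are shown below. What is called first, only, known or untested is meant among the compounds shown, and "the series" means these compounds.

Measured compounds:
- compound 1 `Cc1c(OCCCCOc2ccc(F)c(C(=O)O)c2)ccc(C(=O)CC(C)(C)C)c1O` — 208 nM
- compound 2 `Cc1c(OCCCCOc2ccc(C(=O)CC(C)(C)C)c(O)c2C)cccc1C(=O)O` — 136 nM
- compound 3 `Cc1cc(C(=O)O)ccc1OCCCCOc1ccc(C(=O)C(C)C)c(O)c1C` — 234 nM

In an assay on HEK293 cells for positive allosteric modulation of metabotropic glutamate receptor 2 (Rattus norvegicus), read by thallium flux, with a stated time of 2.5 min (on this read-out lower numbers stand for an effect already at smaller amounts and higher numbers for an effect only at larger amounts of compound), compound 1 gives 208 nM, the second highest of the three numbers; its nearest neighbour is compound 3, and the gap between them lies within the scatter, as does the gap to compound 2. Going by the values given here, the one measured step in this set, a 1.5-fold lower number from compound 1 to compound 2 (0.18 log units; within the scatter), swaps the aryl group on the oxygen on a saturated carbon and stays within the scatter.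

Compound 4 `Cc1c(OCCCCOc2ccc(F)c(C(=O)O)c2)ccc(C(=O)CC(C)C)c1O` is to be measured in this assay. Its difference from compound 1 is hydrogen in place of methyl on a saturated chain carbon bound to three saturated chain carbons, on a saturated chain carbon bound to three saturated chain carbons, which turns the tert-butyl into isopropyl and the neopentylcarbonyl into isobutylcarbonyl.

Among the compounds with values here, no measured step changes this ketone chain alone. Compound 3 carries an isobutyrylcarbonyl together with a different carboxy aryl and gives 234 nM, close to compound 1, so the shortening of the ketone chain does not stand out in the numbers at hand. The step from compound 1 to compound 4 is therefore expected to stay within the scatter, a 1.3-fold higher number from compound 1 to compound 4 (0.10 log units; within the scatter), with a modest lean toward a higher number.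

Compound 4 is estimated at 260 nM, within 110 nM to 650 nM.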

Compound 4, half-maximal effective concentration: 153 nM
Beside the measured number, compound 4's estimate is 1.7-fold (0.23 log units) above it; the range from low to high includes it.
By their numbers in this assay, from the lowest: compounds 2, 4, 1 and 3 (each within the scatter of the next).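

In this assay, going by these compounds alone, a 1.4-fold lower number from compound 1 to compound 4 (0.13 log units; within the scatter) gives the first reading of the ketone chain on its own, with the core of compound 1 and the 3-carboxy-4-fluorophenyl group held constant. Hydrogen in place of methyl on a saturated chain carbon bound to three saturated chain carbons, which turns neopentylcarbonyl into isobutylcarbonyl, therefore leaves compound 1 and compound 4 indistinguishable in this read-out, whereas compound 3 had offered a shorter ketone chain only together with a different carboxy aryl group. No other measurement on these compounds bears on this result, so the closeness of the two numbers stays an observation without an explanation.

On these data alone, whether the same replacement reads the same alongside the 3-carboxy-2-methylphenyl group of compound 2 remains open. Also open, as far as these compounds go, is how this position would respond to a larger departure from tert-butyl and isopropyl, such as a longer straight chain, a cyclopropyl group or an amine, since the two groups compared here differ by a single methyl.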